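The compounds below may be only part of what the source reports. "The series", "measured", "known", "first", "only" and "open" are said of these compounds alone.

Of the compounds shown here, two built on the same dihydropyridine ester have been tested in a functional assay (cardiac atrium) for agonist activity, with Cavia porcellus as the target; on this read-out lower numbers stand for an effect already at smaller amounts and higher numbers for an effect only at larger amounts of compound. Compound 1 `CC1=C(C(=O)OCCO[N+](=O)[O-])C(c2cccc3nonc23)C([N+](=O)[O-])=C(C)C1` carries a short nitrate-bearing ester chain and gives 31100 nM in this assay. Compound 2 `CC1=C(C(=O)O[C@H](C)CO[N+](=O)[O-])[C@H](c2cccc3nonc23)C([N+](=O)[O-])=C(C)C1` adds a methyl branch to that chain and is drawn as a single configuration at both of its stereocentres; in this assay compound 2 gives 1920 nM, the lowest of the two numbers, with compound 1 standing at a clearly higher number beyond the usual scatter.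

Compound 3 `CC1=C(C(=O)O[C@@H](C)CO[N+](=O)[O-])[C@@H](c2cccc3nonc23)C([N+](=O)[O-])=C(C)C1` has not yet been measured. Its relation to compound 2 is this: the two compounds have the same atoms and bonds and differ only in configuration as drawn: 2 of 2 stereo elements differ (all stereocentres are inverted: mirror images); a stereocentre at a saturated chain carbon is drawn R in compound 2 and S in compound 3; a stereocentre at a saturated ring carbon is drawn S in compound 2 and R in compound 3. Among the measured compounds shown here, no measured pair in this set differs only in configuration, so the size of such a step is unknown here. Such pairs often part by a large margin, and the direction is not settled by the data. Compound 3 is expected to give about 8000 nM, in a range from 1500 nM to 45000 nM, which would amount to an estimated step of a 4.2-fold higher number from compound 2 to compound 3 (0.62 log units; beyond the scatter).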

Compound 3, half-maximal effective concentration: 33700 nM
Estimate against measurement, compound 3: 4.2-fold (0.62 log units) below; measured number inside the range.
By their numbers in this assay, from the lowest: compound 2; then compounds 1 and 3 (each within the scatter of the next).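

Inverting both stereocentres gives an 18-fold higher number from compound 2 to compound 3 (1.24 log units; beyond the scatter) in this assay and so shows that at this ester the three-dimensional arrangement matters, not only which atoms are present. The step can be put down to configuration alone, because nothing else separates the pair: the fact that compounds 2 and 3 differ only in the configuration as drawn. The methyl branch alone therefore does not bring the lower number of compound 2, since compound 3 carries the same branch.

Both stereocentres change together, so the compounds shown cannot tell whether the saturated chain carbon, the saturated ring carbon or the two in combination account for the step. From the compounds shown here alone, how an ethyl branch, or a longer chain carrying the nitrate, would behave in either configuration also stays open.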